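From one thiophene swap to ethynyl

A few compounds are considered here, and "the series" means these few. Any claim that something is new, unique, unknown or untested is made for them only; others in the source may bear on it.

Compound 1 `CSc1ncnc2c1c(-c1cccs1)cn2[C@@H]1O[C@H](CO)[C@@H](O)[C@H]1O`: 11600 nM
Compound 2 `CSc1ncnc2c1c(-c1ccsc1)cn2[C@@H]1O[C@H](CO)[C@@H](O)[C@H]1O`: 450 nM

In a functional assay on K562 cells (Homo sapiens), read by MTT assay, with a stated time of 72 h (on this read-out lower numbers stand for stronger inhibition and higher numbers for weaker inhibition), compound 2 holds the lower of the two numbers. Going by the values given here, the only measured step, a 26-fold lower number from compound 1 to compound 2 (1.41 log units; beyond the scatter), is large and lies beyond the scatter. Compound 3 `C#Cc1cn([C@@H]2O[C@H](CO)[C@@H](O)[C@H]2O)c2ncnc(SC)c12` has not yet been measured, and it is defined by ethynyl in place of thiophen-3-yl on an aromatic carbon. The measured step, thiophen-3-yl in place of thiophen-2-yl, falls on this same aromatic carbon, so a large change from a swap here has precedent. However, no measured compound carries ethynyl, and that step gives no direction for this change. The expectation therefore stays close to compound 2 at 450 nM, with a wide margin on both sides. The expected step is a 1.6-fold higher number from compound 2 to compound 3 (0.19 log units; within the scatter), with no clear direction and no expected shift beyond the scatter. For compound 3 the estimated value is 700 nM, with an expected range from 70 nM to 7000 nM.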

Compound 3, half-maximal inhibitory concentration: 30 nM
For compound 3 the middle estimate is 23-fold (1.37 log units) above the measured one, outside the stated range (below it).
By their numbers in this assay, from the lowest: compound 3; then compound 2; then compound 1.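

In this assay the aromatic carbon that carried the thiophene rings also accepts a group with no ring at all: ethynyl gives a 15-fold lower number from compound 2 to compound 3 (1.18 log units; beyond the scatter) and, against the weaker thiophene, a 390-fold lower number from compound 1 to compound 3 (2.59 log units; beyond the scatter) as well. The earlier pair showed only that the choice between thiophen-2-yl and thiophen-3-yl matters at this carbon, whereas compound 3 shows that no aromatic ring is needed here for the lowest number of the three, and that a triple bond outside aromatic rings with far fewer heavy atoms can take the place of the thiophene. No measured evidence on the cause of this step is at hand. The compounds shown leave open whether a vinyl group, a plain methyl or a longer alkyne such as propynyl would keep so low a number at this carbon. They also leave open whether ethynyl would give a step of this size with an amine in place of the methylthio group on the shared core.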